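The source may hold more compounds than are shown below. What is called first, only, known or untested is meant among the compounds shown, and "the series" means these compounds.

Compound 1 `CCCn1c(-c2ccc(OCc3c(-c4c(Cl)cccc4Cl)noc3C(C)C)cc2)nc2ccc(C(=O)O)cc21`: in an assay on Huh-7 cells for agonist activity at Bile acid receptor (Homo sapiens), read by a luciferase reporter (on this read-out lower numbers stand for an effect already at smaller amounts and higher numbers for an effect only at larger amounts of compound), compound 1 gives 9.3 nM.
Compound 2 `CC(C)c1onc(-c2c(Cl)cccc2Cl)c1COc1ccc(-c2nc3ccc(C(=O)O)cc3n2C2CC2)cc1`: in this assay compound 2 gives 16.5 nM.

Among the compounds with values here, on these two numbers compound 2 stands at the higher end, with compound 1 as its only neighbour; the step of a 1.8-fold higher number from compound 1 to compound 2 (0.25 log units; within the scatter) lies within the scatter, so the two compounds cannot be told apart on this read-out.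

Compound 3 `CC(C)c1onc(-c2c(Cl)cccc2Cl)c1COc1ccc(-c2nc3ccc(C(=O)O)cc3n2C2CCCCCC2)cc1` has not been measured. It differs from compound 2 in one place: cycloheptyl in place of cyclopropyl on an aromatic nitrogen.

Within the data shown here, only one measured step concerns the group on this aromatic nitrogen, the step from propyl to cyclopropyl, a 1.8-fold higher number from compound 1 to compound 2 (0.25 log units; within the scatter), and it did not move the number beyond the scatter. Among the measured compounds shown here, that step exchanged groups of similar size; the change to cycloheptyl adds considerably more to the ring than either of the measured groups carries, and no measured compound shows what a group of this size does at this position. Compound 3 is therefore expected to give a number somewhat higher than compound 2, a 2.4-fold higher number from compound 2 to compound 3 (0.38 log units; beyond the scatter), with wide uncertainty. The estimate for compound 3 in this assay is 40 nM, between 8 nM and 250 nM.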

Compound 3, half-maximal effective concentration: 14.8 nM
The estimate for compound 3 lay 2.7-fold (0.43 log units) above the measured number; measured number inside the range.
By their numbers in this assay, from the lowest: compounds 1, 3 and 2 (each within the scatter of the next).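

Cyclopropyl, with 3 heavy atoms, and cycloheptyl, with 7 heavy atoms, both sit on the aromatic nitrogen, yet exchanging one for the other gives no distinguishable response in this assay: the step is a 1.1-fold lower number from compound 2 to compound 3 (0.05 log units; within the scatter). The comparison with the open chain reads the same way, at a 1.6-fold higher number from compound 1 to compound 3 (0.20 log units; within the scatter), so propyl, cyclopropyl and cycloheptyl cannot be told apart at this position, and compound 1 and compound 2 alone could not show that this holds for a seven-membered ring of carbon as well. No supporting data are available that would account for this result.

All three groups are built of carbon only, so the compounds shown leave open whether an amine, a hydroxyl group or an ether oxygen carried on a ring or chain at this nitrogen would stay in the same range. They also leave open whether a longer chain such as octyl, a branched group such as tert-butyl or an aromatic ring such as phenyl would do so, and how far the range of groups that cannot be told apart extends.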